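Pyrrolidine carboxamide in place of the diamine chain

A few compounds are considered here, and "the series" means these few. Any claim that something is new, unique, unknown or untested is made for them only; others in the source may bear on it.

Compound 2 `CNCCCNc1c(F)cc2c(=O)c(C(=O)O)cn(Cc3ccc(-c4ccccc4)cc3)c2c1OC` gives 101000 nM in an assay on isolated protein for inhibition of DNA topoisomerase 1 (Homo sapiens), with a stated time of 15 min (on this read-out higher numbers stand for weaker inhibition and lower numbers for stronger inhibition), and holds the highest of the two numbers shown; the nearest is compound 3 `CNCCCNc1cc2c(cc1F)c(=O)c(C(=O)O)cn2Cc1ccc(-c2ccccc2)cc1` at 63600 nM, with a 1.6-fold lower number from compound 2 to compound 3 (0.20 log units; within the scatter). Compound 1 `COc1c(N2CC[C@@H](CO)C2)c(F)cc2c(=O)c(C(=O)O)cn(Cc3ccc(-c4ccccc4)cc3)c12` gives only a limit in this assay, > 200000 nM. Compound 4 `COc1c(N2CC[C@@H](C(N)=O)C2)c(F)cc2c(=O)c(C(=O)O)cn(Cc3ccc(-c4ccccc4)cc3)c12` is compound 2 with 3-carbamoylpyrrolidin-1-yl in place of (3-(methylamino)propyl)amino on an aromatic carbon. Among the measured compounds shown here, the one measured step bearing on this change runs the other way, an at least 1.9-fold lower number from compound 1 to compound 2 (0.29 log units; that floor lies within the scatter), and is a floor only because of the limit of > 200000 nM in this assay, at which 1 of the 3 values shown sits. Compound 4 differs from compound 1 only in carbamoyl in place of hydroxymethyl on the pyrrolidine. An increase in the number is therefore expected, a 2.0-fold higher number from compound 2 to compound 4 (0.30 log units; within the scatter), possibly back to the limit. Compound 4 is estimated at 200000 nM, within 80000 nM to 500000 nM.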

Compound 4, half-maximal inhibitory concentration: > 200000 nM
Compound 4 was reported as a limit (the forecaster's own chance of this, stated with the estimate: 50%); the middle value sits exactly at the limit.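

In this assay compound 4 gives only a limit, > 200000 nM, so a second substituted pyrrolidine at this position, after compound 1, yields no number. The change from the diamine chain can be read only as a floor, an at least 1.9-fold higher number from compound 2 to compound 4 (0.29 log units; that floor lies within the scatter). The step from hydroxymethyl to carbamoyl on the pyrrolidine cannot be read: the limit of > 200000 nM in this assay, at which 2 of the 4 values shown sit.

As far as these compounds go, whether a pyrrolidine with an amine in place of carbamoyl gives a readable number at this position stays open. So does how far beyond the limit the true values of compound 1 and compound 4 lie.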